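The source may report more compounds than this note shows. Statements on the series, on what has been measured and on what is new or still open speak of the compounds shown alone.

Measured so far:
compound 1, `O=C(/C=C\c1ccc(O)cc1)N1N=C(c2ccncc2)OC1c1c[nH]c2ccccc12`: > 30 ug/mL
compound 2, `O=C(/C=C\c1ccc(F)cc1)N1N=C(c2ccncc2)OC1c1c[nH]c2ccccc12`: > 30 ug/mL

Both values come from an ADME assay on A549 cells (Homo sapiens) for cytotoxicity, read by MTT assay, with a stated time of 48 h; on this read-out lower numbers stand for stronger inhibition of growth and higher numbers for weaker inhibition of growth. In this assay compound 1 gives > 30 ug/mL, which is a limit of the assay and not a number. Compound 2 gives > 30 ug/mL in this assay, again a limit and not a number. For the measured compounds named here, compound 2 thus stands at the edge of what this assay reports, and the one further value shown is a limit as well, so no ordering of the two can be read. Going by the values given here, the single step available, a step that the two limits leave unreadable from compound 1 to compound 2, fluoro in place of hydroxy on an aromatic carbon, stays unreadable because both of its ends sit at the limit of > 30 ug/mL in this assay, at which 2 of the 2 values shown sit.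

Compound 3, `O=C(/C=C\c1cccc(Cl)c1Cl)N1N=C(c2ccncc2)OC1c1c[nH]c2ccccc12`, has not yet been measured in this assay. It differs from compound 2 by 2,3-dichlorophenyl in place of 4-fluorophenyl on a double-bonded chain carbon bound to a double-bonded chain carbon. No measured step carries a change of this kind, and the only step shown gives no readable size, so nothing measured points to a step in either direction beyond the scatter. Compound 3 is therefore expected to stay near the same limit, with a step that the limit leaves unreadable from compound 2 to compound 3 expected in this assay. Compound 3 is estimated at 40 ug/mL, with an expected range of 20 ug/mL to 100 ug/mL.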

Compound 3, concentration for 50% growth inhibition: > 30 ug/mL
Compound 3: a limit, no number (the forecaster's own chance of this, stated with the estimate: 80%); the middle value does not contradict the limit.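

No step among compound 1, compound 2 and compound 3 can be read in this assay, because both ends of each step are limits and not numbers: the limit of > 30 ug/mL in this assay, at which 3 of the 3 values shown sit.

The compounds shown leave open how these three compare with one another, and whether any substituted phenyl group at this place gives a measurable value.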